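The source may hold more compounds than are shown below. What is called first, only, known or untested is meant among the compounds shown, and "the series" means these compounds.

Two compounds have been measured in a functional assay on SK-OV-3 cells (Homo sapiens) for antiproliferative activity, read by MTT assay, with a stated time of 72 h; a higher number here means a weaker inhibitor, a lower number a stronger inhibitor:

compound 1, `CC(=O)Oc1ccc(N2C(=O)/C(=C/N3N=C(c4ccc(Cl)cc4)CC3c3ccc(Cl)cc3)SC2=S)cc1`, gives > 10000 nM, which is a limit of the assay rather than a number.
compound 2, `CC(=O)Oc1ccc(N2C(=O)/C(=C/N3N=C(c4ccc5ccccc5c4)CC3c3ccccc3O)SC2=S)cc1`, gives > 10000 nM, likewise a limit rather than a number.

Compound 2 therefore stands at the ceiling of what this assay can report, and the same holds for compound 1, so that (the limit of > 10000 nM in this assay, at which 2 of the 2 values shown sit). Going by the values given here, with both values sitting at that limit, no ordering between compound 1 and compound 2 can be drawn, and no measured step is available.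

Compound 3, `CC(=O)Oc1ccc(N2C(=O)/C(=C/N3N=C(c4ccc5ccccc5c4)CC3c3ccc(Cl)cc3)SC2=S)cc1`, keeps the naphthalen-2-yl group of compound 2 and changes one ring substituent: 4-chlorophenyl in place of 2-hydroxyphenyl on a saturated ring carbon. Among the compounds with values here, the group that enters is the one that compound 1 carries at the same ring carbon.

Since compound 2 sits at the limit, and compound 1 sits there too with the same 4-chlorophenyl in place, the step that the limit leaves unreadable from compound 2 to compound 3 is expected to be none beyond the scatter, most likely with compound 3 again reported only as a limit. Compound 3 is thus estimated at 15000 nM in this assay, within a range from 5000 nM to 50000 nM.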

Compound 3, half-maximal inhibitory concentration: > 10000 nM
Compound 3: a limit, no number (the forecaster's own chance of this, stated with the estimate: 75%); the middle value lies beyond the limit too.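

Compound 3 is again reported only as a limit and not as a number, so no step can be read from compound 2 to compound 3 or from compound 1 to compound 3: the limit of > 10000 nM in this assay, at which 3 of the 3 values shown sit.

The compounds shown leave open how far compound 1, compound 2 and compound 3 differ in this assay, and whether either group swap changes activity at all.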